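One Carbon Fewer Between Ring and Chain: Compound 4

This account rests on a few compounds, and the source may have more. Where it says the series, first, only, none or still open, it means among the compounds named here.

Compound 1 `O=C1NC(=O)/C(=C/C(Cc2ccccc2)c2ccc(-c3ccc4cccc(F)c4c3)[nH]c2=O)O1`: 33 nM
Compound 2 `CC(C)C(CC1NC(=O)NC1=O)c1ccc(-c2ccc3cccc(F)c3c2)[nH]c1=O`: 10 nM
Compound 3 `CCC(/C=C1\OC(=O)NC1=O)(CC)c1ccc(-c2ccc3cccc(C(F)(F)F)c3c2)[nH]c1=O`: 230 nM

All three were measured in an assay on membranes from Chem-1 cells for displacement of a labelled ligand from prostaglandin E2 receptor EP3 subtype (Homo sapiens), read by scintillation counting, with a stated time of 2 h; on this read-out higher numbers stand for weaker inhibition and lower numbers for stronger inhibition. Compound 2 has the lowest number of the three; compound 1 sits clearly higher, beyond the usual scatter, and compound 3 is the furthest away. Compound 4 `CC(C)C(c1ccc(-c2ccc3cccc(F)c3c2)[nH]c1=O)C1NC(=O)NC1=O` is compound 2 with the linking carbon removed: 2,5-dioxoimidazolidin-4-yl in place of (2,5-dioxoimidazolidin-4-yl)methyl on a saturated chain carbon bound to an aromatic carbon and a saturated chain carbon. Within the data shown here, no measured pair shows this exact change, so the expectation rests on compound 2 alone. In this assay a modest loss is expected, a step of a 2.5-fold higher number from compound 2 to compound 4 (0.40 log units; beyond the scatter), which may or may not exceed the scatter. For compound 4 the estimate is 25 nM, within a range from 8 nM to 80 nM.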

Compound 4, inhibition constant: 50 nM
For compound 4 the middle estimate is 2.0-fold (0.30 log units) below the measured one; the measured number falls inside the stated range.
By their numbers in this assay, from the lowest: compound 2; then compounds 1 and 4 (each within the scatter of the next); then compound 3.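

In this assay, 2,5-dioxoimidazolidin-4-yl in place of (2,5-dioxoimidazolidin-4-yl)methyl gives a 5.0-fold higher number from compound 2 to compound 4 (0.70 log units; beyond the scatter), so inhibition weakens. Among these compounds, this is the first comparison here in which only one place changes, and it shows that the linking carbon counts at this position even though the ring itself and its hydrogen-bond donors and acceptors stay the same. On these data alone, whether the longer 2-(2,5-dioxoimidazolidin-4-yl)ethyl group would strengthen or weaken inhibition at this position stays open. Nothing in the data shown explains the weakening.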